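Propyl, methyl and butyl ethers on the aryl ring

The compounds below may be only part of what the source reports. "The series", "measured", "known", "first", "only" and "open" are said of these compounds alone.

Measured so far:
- compound 1, `CCCOc1ccc([C@@H]2CC(=O)c3cc(CC=C(C)C)c(OC)cc3O2)cc1`: in a functional assay on PC-3 cells (Homo sapiens) for inhibition, read by sulforhodamine B assay, with a stated time of 48 h, tested at 50 uM (a lower number here means less inhibition of growth, a higher number more inhibition of growth at the concentration tested), compound 1 gives 54%
- compound 2, `COc1ccc([C@@H]2CC(=O)c3cc(CC=C(C)C)c(OC)cc3O2)cc1`: in this assay compound 2 gives 58%
- compound 3, `CCCCOc1ccc([C@@H]2CC(=O)c3cc(CC=C(C)C)c(OC)cc3O2)cc1`: in this assay compound 3 gives 48%

All three share one core and differ only in the ether chain on the aryl ring. The step of a number 4 percentage points higher from compound 1 to compound 2 (within the scatter) and the step of a number 10 percentage points lower from compound 2 to compound 3 (within the scatter) are both within the scatter, as is a number 6 percentage points lower from compound 1 to compound 3 (within the scatter); compound 3 has the lowest of the three numbers, but none of these gaps is large enough to read as a trend.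

Compound 4, `CCOc1ccc([C@@H]2CC(=O)c3cc(CC=C(C)C)c(OC)cc3O2)cc1`, is not yet measured. It differs from compound 3 by hydrogen in place of ethyl on a saturated chain carbon, two bonds along the chain from an oxygen on an aromatic ring. The same kind of change, (hydrogen in place of ethyl on a saturated chain carbon bound to an oxygen on an aromatic ring), is already measured once and gave a number 4 percentage points higher from compound 1 to compound 2 (within the scatter). The places are not identical: in that pair the ethyl sits on a saturated chain carbon bound to an oxygen on an aromatic ring, whereas in compound 3 to compound 4 it sits two bonds along the chain from that oxygen. The cores of compound 1 and compound 3 differ by methyl in place of hydrogen on a saturated chain carbon, three bonds along the chain from an oxygen on an aromatic ring.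

Since the earlier step was within the scatter, the step from compound 3 to compound 4 is expected to be a number 6 percentage points higher from compound 3 to compound 4 (within the scatter), likewise small. Compound 4 is expected to give 54% in this assay, between 44% and 64%.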

Compound 4, percent growth inhibition at one concentration: 60%
Beside the measured number, compound 4's estimate is 6 percentage points below it, and the stated range covers the measured number.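

In this assay, going by these compounds alone, butoxy to ethoxy gives a number 12 percentage points higher from compound 3 to compound 4 (beyond the scatter), the only step in this set beyond the scatter, while the other two new steps, a number 2 percentage points higher from compound 2 to compound 4 (within the scatter) and a number 6 percentage points higher from compound 1 to compound 4 (within the scatter), stay small. Replacing ethyl with hydrogen on the ether chain can be compared on two cores, and the two steps do not differ beyond what such a pair can scatter: the same change on two cores in this assay, a number 4 percentage points higher (within the scatter) from compound 1 to compound 2 and a number 12 percentage points higher (beyond the scatter) from compound 3 to compound 4, 8 percentage points apart, within the scatter of two such steps. Replacing hydrogen with methyl on the chain reads the same way, so each change carries from one core to the other without a detectable difference, although a single pair per change does not show that either step is constant across the series: the same change on two cores in this assay, a number 6 percentage points lower (within the scatter) from compound 1 to compound 3 and a number 2 percentage points higher (within the scatter) from compound 2 to compound 4, 8 percentage points apart, within the scatter of two such steps.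

The compounds shown leave open how the read-out in this assay behaves with a chain longer than butoxy, or with a branched chain. They also leave open whether an ether chain carrying an amine or a carboxylic acid would fall within the same range.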